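Swapping the acid of compound 1 for an amide

This account rests on a few compounds, and the source may have more. Where it says the series, first, only, none or still open, it means among the compounds named here.

compound 1 `O=C(O)CCCCC(CCSC(=O)c1ccccc1)SC(=O)c1ccccc1` gives 89.8%
compound 2 `O=C(CCCCC(S)CCS)Nc1cccc(C(F)(F)F)c1` gives 30.5%
compound 3 `CC(=O)SCCC(CCCCC(=O)Nc1ccc(Cl)cc1)SC(C)=O` gives 72%

All three values come from a functional assay on KB cells (Homo sapiens) for inhibition, read by MTT assay, with a stated time of 24 h, tested at 100 ug/mL (a higher number here means more inhibition of growth at the concentration tested, a lower number less inhibition of growth), and can be compared directly. Compound 1 stands highest of the three. The gaps down to compound 3 (72%) and to compound 2 (30.5%) both lie beyond the usual scatter.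

Compound 4 `O=C(CCCCC(CCSC(=O)c1ccccc1)SC(=O)c1ccccc1)Nc1ccccc1Cl` keeps the core of compound 1 and changes one place. It has (2-chlorophenyl)amino in place of hydroxy on a carbonyl carbon, so a carboxy group becomes a (2-chlorophenyl)carbamoyl group (2-chlorophenyl)amino in place of hydroxy on a carbonyl carbon and the acid becomes an amide.

Going by the values given here, no measured pair isolates this change, so the evidence is indirect. Compound 3 also carries an amide with a chlorine-bearing ring and gives 72% while compound 2, another amide, gives 30.5% and differs more from compound 4 at its sulfur atoms. Both amides read lower than compound 1, but three compounds support only a cautious expectation.

In this assay the expected change is a moderate fall, estimated as a number 17.8 percentage points lower from compound 1 to compound 4 (beyond the scatter) and not certain to clear the scatter. Compound 4 is expected at 72% (estimated range 48% to 92%).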

Compound 4, percent growth inhibition at one concentration: "not active" (no number reported)
Nothing numeric was reported for compound 4, and the estimate cannot be compared.
By their numbers in this assay, from the lowest: compound 2; then compound 3; then compound 1.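

In this assay, going by these compounds alone, compound 4 is reported only as not active, with no number, so no step from compound 1 to compound 4 can be read. The compounds shown leave open how large the change from hydroxy to (2-chlorophenyl)amino is in this read-out. Nothing shown here offers an explanation for the result of compound 4.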